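Hydrazone series: halogenated aryl replacing dimethylphenyl

The compounds below may be only part of what the source reports. "The series", "measured", "known", "first", "only" and "open" are said of these compounds alone.

Compound 2 `Cc1cc(C)cc(NN=C2CCC(C)n3c2ncc(C(=O)O)c3=O)c1` carries a carboxylic acid on the shared core with a 3,5-dimethylphenyl hydrazone. In a functional assay on the whole organism with Rattus norvegicus as the target (on this read-out higher numbers stand for an effect only at larger amounts of compound and lower numbers for an effect already at smaller amounts), compound 2 gives only a limit, > 320 umol/kg, and no number. Compound 3 `Cc1cc(C)c(NN=C2CCC(C)n3c2ncc(C(=O)O)c3=O)cc1C` differs in the aryl substitution; in this assay compound 3 gives 320 umol/kg. Compound 1 `CC1CCC(=NNc2ccccc2)c2ncc(C(=O)NO)c(=O)n21` carries a hydroxamic acid in place of the carboxylic acid and an unsubstituted phenyl; in this assay compound 1 also gives only a limit, > 100 umol/kg. Among the measured compounds shown here, of the three values shown, two are limits the limit of > 100 umol/kg in this assay, at which 1 of the 3 values shown sits (the limit of > 320 umol/kg in this assay, at which 1 of the 3 values shown sits), so compound 2 stands at the weak end of what the assay can report and no measured step between compounds is available.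

Compound 4 `CC1CCC(=NNc2ccc(Br)cc2Cl)c2ncc(C(=O)O)c(=O)n21` changes the aryl group on the hydrazone: 4-bromo-2-chlorophenyl in place of 3,5-dimethylphenyl on an amine nitrogen. For the measured compounds named here, with no measured step to lean on, the step from compound 2 to compound 4 is expected to be small, an at least 1.2-fold lower number from compound 2 to compound 4 (0.10 log units; that floor lies within the scatter), and a limit remains a real possibility. In this assay compound 4 is expected to give roughly 250 umol/kg, within 80 umol/kg to 800 umol/kg.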

Compound 4, dose for 50% inhibition: > 100 umol/kg
Compound 4: only a limit was reported (the forecaster's own chance of this, stated with the estimate: 50%); the middle value does not contradict the limit.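

In this assay compound 4 gives only a limit, > 100 umol/kg. Among the compounds shown here, compound 2 likewise gives only a limit, > 320 umol/kg, so no step from compound 2 to compound 4 can be read. From the compounds shown here alone, whether 4-bromo-2-chlorophenyl in place of 3,5-dimethylphenyl shifts the read-out at all remains open.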